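The compounds below may be only part of what the source reports. "The series", "measured", "known", "first", "only" and "open" are said of these compounds alone.

Measured so far:
- compound 1, `Cc1cc(-c2cccc(F)c2)c2ncc(CSCCc3ccccc3)n2c1`: 35 ug/mL
- compound 2, `Cc1cc(-c2ccc(O)cc2)cn2c(CSCCc3ccccc3)cnc12`: > 50 ug/mL

Compound 1 was tested in an ADME assay on HEL cells (Homo sapiens) for cytotoxicity, with a stated time of 3 days (on this read-out lower numbers stand for higher toxicity in this test and higher numbers for lower toxicity in this test), and gives 35 ug/mL. For compound 2 the assay reports > 50 ug/mL, which is a limit of the test and not a number. Within the data shown here, compound 1 therefore stands as the only definite number among the two results; the other result is the limit of > 50 ug/mL in this assay, at which 1 of the 2 values shown sits.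

Compound 3 `Cc1cc(-c2cccc(O)c2)c2ncc(CSCCc3ccccc3)n2c1` has not yet been measured. It differs from compound 1 in one place: hydroxy in place of fluoro on an aromatic carbon. Among the measured compounds shown here, no pair of measured compounds shows this exact change, so its size has to be guessed. Compound 2 also carries a hydroxy group on its outer ring, and it sits at the limit rather than at a number. That points, weakly, toward the same direction for compound 3.

The step from compound 1 to compound 3 in this assay is expected to be small, toward lower toxicity, and possibly no larger than the scatter: a 1.4-fold higher number from compound 1 to compound 3 (0.15 log units; within the scatter). Compound 3 is thus estimated at 50 ug/mL, with a range from 25 ug/mL to 100 ug/mL.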

Compound 3, half-maximal cytotoxic concentration: 11.4 ug/mL
Beside the measured number, compound 3's estimate is 4.4-fold (0.64 log units) above it, outside the stated range (below it).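

Among these compounds, replacing 3-fluorophenyl with 3-hydroxyphenyl on the shared core gives the first change that can be read directly in this assay, and it produces a 3.1-fold lower number from compound 1 to compound 3 (0.49 log units; beyond the scatter). This shows that the position is sensitive: exchanging one heavy atom for another, while adding a hydrogen-bond donor and a hydrogen-bond acceptor, moves the read-out toward higher toxicity in this test by more than the usual scatter. Compound 2 also carries a hydroxy group, but its result is only a limit and not a number, and it differs from compound 3 in more than one place, so no step between them can be read and no general effect of hydroxy can be claimed: the limit of > 50 ug/mL in this assay, at which 1 of the 3 values shown sits.

A single pair cannot show which feature of the hydroxy group accounts for the shift, so its cause remains unknown. Going by these compounds, what a methoxy group or an amine would do in the same place also stays open, as does whether the shift is specific to hydroxy or would appear with other replacements for fluoro.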